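A few compounds are considered here, and "the series" means these few. Any claim that something is new, unique, unknown or untested is made for them only; others in the source may bear on it.

In a functional assay on RS4-11 cells (Homo sapiens) for inhibition, read by CCK-8 assay, with a stated time of 48 h, tested at 20 uM (a lower number here means less inhibition of growth, a higher number more inhibition of growth at the concentration tested), three compounds have been measured:

- compound 1 `COc1ccc(Cc2nnc(NC(=O)/C(C#N)=C/c3ccccc3OS(=O)(=O)c3ccc(Cl)cc3)s2)cc1`: 79%
- compound 2 `N#C/C(=C\c1ccccc1OS(=O)(=O)c1ccc(Cl)cc1)C(=O)Nc1nnc(Cc2cccc3ccccc23)s1`: 68%
- compound 3 `N#C/C(=C\c1ccccc1OS(=O)(=O)c1ccc([N+](=O)[O-])cc1)C(=O)Nc1nnc(Cc2ccc(F)cc2)s1`: 55%

Compound 3 stands lowest of the three, and its gaps to compound 2 and compound 1 both lie beyond the scatter. The next compound, compound 4 `N#C/C(=C\c1ccccc1OS(=O)(=O)c1ccc(Cl)cc1)C(=O)Nc1nnc(Cc2ccc(F)cc2)s1`, departs from it in one place: chloro in place of nitro on an aromatic carbon. The 4-nitrophenyl group thus becomes 4-chlorophenyl.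

Among the measured compounds shown here, no measured step covers this exchange. For the measured compounds named here, the only step available, a number 11 percentage points lower from compound 1 to compound 2 (beyond the scatter), is modest and concerns a different change, naphthalen-1-yl in place of 4-methoxyphenyl, so it gives only a rough idea of how far one change can move this assay. The more useful hint comes from the values themselves. Compound 1 at 79% and compound 2 at 68% both carry the (4-chlorophenyl)sulfonyl group that compound 4 has, although each also differs from compound 3 elsewhere. An upward move of modest to moderate size is therefore expected, with real uncertainty, as the effect of this exchange has not been measured directly. The estimated step is a number 13 percentage points higher from compound 3 to compound 4 (beyond the scatter). Compound 4 is expected at 68%, with an estimated range from 54% to 82%.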

Compound 4, percent growth inhibition at one concentration: 68%
For compound 4 middle estimate and measured number coincide at the digits printed, and the stated range covers the measured number.
By their numbers in this assay, from the lowest: compound 3; then compounds 2 and 4 (each within the scatter of the next); then compound 1.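

In this assay, among the compounds shown here, the step of a number 13 percentage points higher from compound 3 to compound 4 (beyond the scatter) is the first direct reading at this position, on an aromatic carbon para to a large group, and it shows that chloro in place of nitro moves the result beyond the scatter with the rest of the molecule unchanged. For the compounds shown here, compound 4 also links this exchange to the earlier compounds: with the (4-chlorophenyl)sulfonyl group held constant, 4-fluorophenyl in place of naphthalen-1-yl gives no change at the digits printed from compound 2 to compound 4 (within the scatter), whereas fluoro in place of methoxy gives a number 11 percentage points lower from compound 1 to compound 4 (beyond the scatter), so the methoxy-bearing compound 1 stays on top in this set. No available evidence accounts for any of these steps.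

Only nitro and chloro are compared at this position, so the compounds shown leave open how an amine or a carboxylic acid there would read. They also leave open whether chloro in place of nitro gives a step of similar size when the saturated chain carbon bears 4-methoxyphenyl or naphthalen-1-yl rather than 4-fluorophenyl.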